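Chloro for fluoro on the benzyl ring of compound 1

The source may hold more compounds than are shown below. What is called first, only, known or untested is meant among the compounds shown, and "the series" means these compounds.

Two compounds have been run in a physicochemical assay, with a stated time of 30 min (on this read-out lower numbers stand for stronger inhibition and higher numbers for weaker inhibition), so far. Compound 1 `C/C(=N\N=C1/SCC(=O)N1Cc1cccc(F)c1)c1cccs1` gives 21100000 nM. Compound 2 `C/C(=N/N=C1\SCC(=O)N1Cc1ccc(F)cc1)c1ccccn1` gives 16200000 nM in this assay. On these two numbers compound 1 and compound 2 lie within the usual scatter of each other, so no difference between them can be read. Compound 3 `C/C(=N\N=C1/SCC(=O)N1Cc1cccc(Cl)c1)c1cccs1` differs from compound 1 by chloro in place of fluoro on an aromatic carbon. Going by the values given here, no measured pair shows this change, so the expected step from compound 1 to compound 3 in this assay is small, a 1.4-fold lower number from compound 1 to compound 3 (0.15 log units; within the scatter), and may not exceed the scatter. Compound 3 is therefore estimated at 15000000 nM, within 5000000 nM to 45000000 nM.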

Compound 3, half-maximal inhibitory concentration: 20300000 nM
The estimate for compound 3 lay 1.4-fold (0.13 log units) below the measured number, within the range that was stated.
By their numbers in this assay, from the lowest: compounds 2, 3 and 1 (each within the scatter of the next).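

In this assay, going by these compounds alone, the change from 3-fluorophenyl to 3-chlorophenyl gives a 1.0-fold lower number from compound 1 to compound 3 (0.02 log units; within the scatter) and is the first direct reading at this position. Between these two halogens on the ring, no difference can be read on this read-out. No measurement at hand bears on the reason for this result.

Going by these compounds, whether an amine, a carboxylic acid or a methoxy group at this same position would give a step beyond the scatter remains open. Also open, on these data alone, is whether the same swap of halogens reads alike on the pyridine-bearing compound 2 series.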